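Swapping benzyl for pyridin-3-yl on a saturated ring carbon

A few compounds are considered here, and "the series" means these few. Any claim that something is new, unique, unknown or untested is made for them only; others in the source may bear on it.

In a physicochemical assay for solubility (a lower number here means a less soluble compound, a higher number a more soluble compound), compound 1 `Nc1ccccc1NC(=O)c1ccc(CSC2=N[C@@H](c3ccccc3)CN2)cc1` gives 116 ug/mL and compound 2 `Nc1ccccc1NC(=O)c1ccc(CSC2=N[C@@H](Cc3ccccc3)CO2)cc1` gives 31 ug/mL as the lower of the two numbers, a gap beyond the usual scatter. Compound 3 `Nc1ccccc1NC(=O)c1ccc(CSC2=N[C@@H](c3cccnc3)CO2)cc1` carries pyridin-3-yl in place of benzyl on a saturated ring carbon. Among the measured compounds shown here, no measured pair shows this change alone, so any forecast here is a judgement. An upward move beyond the scatter is expected in this assay with a 2.9-fold higher number from compound 2 to compound 3 (0.46 log units; beyond the scatter) as the estimated step. Compound 3 is estimated at 90 ug/mL with an expected range from 35 ug/mL to 230 ug/mL in this measurement.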

Compound 3, solubility: 108 ug/mL
The estimate for compound 3 lay 1.2-fold (0.08 log units) below the measured number; measured number inside the range.
By their numbers in this assay, from the lowest: compound 2; then compounds 3 and 1 (each within the scatter of the next).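

In this assay, putting pyridin-3-yl in place of benzyl on this saturated ring carbon, next to the ring nitrogen, gives a 3.5-fold higher number from compound 2 to compound 3 (0.54 log units; beyond the scatter). This pair differs in one place only, so it shows that the group on this carbon can shift the read-out by more than the scatter. Nothing measured here explains the rise.

The swap changes two things at once: one carbon leaves and a ring nitrogen enters. A pyridin-3-ylmethyl group on the same carbon would help tell these two changes apart.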